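A few compounds are considered here, and "the series" means these few. Any claim that something is new, unique, unknown or untested is made for them only; others in the source may bear on it.

Measured compounds:
compound 1 `COc1cc(Cl)cc(-c2nn(-c3cccc(NC(=O)Nc4ccc(Cl)c(C(F)(F)F)c4)c3)cc2-c2ccncc2)c1`: 97% in a functional assay on NCI-H226 cells (Homo sapiens) for inhibition, read by sulforhodamine B assay, with a stated time of 48 h, tested at 0.01 uM; on this read-out higher numbers stand for a weaker effect at the one concentration tested and lower numbers for a stronger effect
compound 2 `COc1cc(Cl)cc(-c2nn(-c3cccc(NC(=O)Nc4ccc(Cl)c(Cl)c4)c3)cc2-c2ccncc2)c1`: 96% in this assay
compound 3 `COc1cc(Cl)cc(-c2nn(-c3cccc(NC(=O)Nc4cccc(C(F)(F)F)c4)c3)cc2-c2ccncc2)c1`: 95% in this assay

Compound 3 has the lowest of the three numbers, with compound 2 nearest and compound 1 furthest, but both gaps lie within the scatter, so the three cannot be told apart on this read-out. The measured steps, a number 1 percentage points lower from compound 1 to compound 2 (within the scatter), a number 2 percentage points lower from compound 1 to compound 3 (within the scatter) and a number 1 percentage points lower from compound 2 to compound 3 (within the scatter), all fall within the scatter; each alters only the aryl group carried on the amide-type nitrogen.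

Compound 4 `COc1cc(Cl)cc(-c2nn(-c3cccc(NC(=O)c4cccc(C(F)(F)F)c4)c3)cc2-c2ccncc2)c1` is not yet measured. It differs from compound 3 by 3-(trifluoromethyl)phenyl in place of (3-(trifluoromethyl)phenyl)amino on a carbonyl carbon. Within the data shown here, no measured step touches the carbonyl carbon, so none bears on this change directly. What the series does show is that every measured compound sits near the top of the read-out at this concentration and that none of the three variations tried moved it beyond the scatter. For compound 4 the same is expected: a step of no change at the digits printed from compound 3 to compound 4 (within the scatter) is expected, which is to say none beyond the scatter. Compound 4 is therefore estimated at 95% in this assay, with a range of 85% to 100%.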

Compound 4, a percentage reported as activity, at one concentration (the size of the read-out at that concentration, not a potency): 95%
Compound 4: middle estimate and measured number agree at the digits printed, and the stated range covers the measured number.
By their numbers in this assay, from the lowest: compounds 3, 4, 2 and 1 (each within the scatter of the next).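

Up to compound 3, the steps in this assay changed only the aryl group on the amide-type nitrogen; compound 4 instead alters the connection itself, with 3-(trifluoromethyl)phenyl on the carbonyl carbon in place of (3-(trifluoromethyl)phenyl)amino, going from 1 hydrogen-bond donor in the leaving group to 0 hydrogen-bond donors in the entering one. The result is no change at the digits printed from compound 3 to compound 4 (within the scatter), and the comparisons with the other two compounds give a number 1 percentage points lower from compound 2 to compound 4 (within the scatter) and a number 2 percentage points lower from compound 1 to compound 4 (within the scatter), so at this one concentration the read-out separates this change on the carbonyl carbon no better than it separated the aryl variations. No supporting measurement is available that bears on this result.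

From the compounds shown here alone, with all four compounds close together near the top of the read-out at a single concentration, it remains open whether the change from compound 3 to compound 4 would show any difference under conditions where the compounds give a stronger effect. Also open, going by these compounds, is whether an amine, a carboxylic acid or a longer chain on the carbonyl carbon, in place of 3-(trifluoromethyl)phenyl, would move the number beyond the scatter.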